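The source may report more compounds than this note shows. Statements on the series, on what has been measured and on what is new or still open speak of the compounds shown alone.

Measured so far, each read in a functional assay on HepG2 cells (Homo sapiens) for inhibition, read by MTT assay, with a stated time of 72 h; on this read-out higher numbers stand for weaker inhibition and lower numbers for stronger inhibition:

Compound 1, `Cc1ccc(-n2cc(CNC(=O)c3cccc4c3cnn4C(C)C)nn2)cc1C`, gives > 40000 nM, which is a limit of the assay and not a number.
Compound 2, `CC(C)n1ncc2c(C(=O)NCc3cn(-c4ccc(F)cc4)nn3)cccc21`, gives > 40000 nM, again a limit of the assay.
Compound 3, `Cc1ccccc1-n1cc(CNC(=O)c2cccc3c2cnn3C(C)C)nn1`, gives > 40000 nM, likewise a limit of the assay.

Compound 3 therefore stands at the limit of > 40000 nM in this assay, at which 3 of the 3 values shown sit, and nothing on the numbers shown separates it from the other two. The steps between the measured compounds reflect this: a step that the two limits leave unreadable from compound 1 to compound 2, a step that the two limits leave unreadable from compound 1 to compound 3 and a step that the two limits leave unreadable from compound 2 to compound 3 all sit between two limits and have no readable size, so none of them tells how the group on the aromatic nitrogen moves the read-out.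

Compound 4, `CC(C)n1ncc2c(C(=O)NCc3cn(-c4ccc(C(F)(F)F)cc4)nn3)cccc21`, differs from compound 3 in one place: 4-(trifluoromethyl)phenyl in place of 2-methylphenyl on an aromatic nitrogen. All three measured steps bear on this position, yet each is unreadable, so no direction or size can be drawn from them for this assay. With every measured compound sitting at the same limit, the expectation for compound 4 is that it stays in the same region, and the step from compound 3 is expected as a step that the limit leaves unreadable from compound 3 to compound 4. The estimate for compound 4 in this assay is 45000 nM, with a range from 15000 nM to 120000 nM, and most likely the assay again reports only a limit.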

Compound 4, half-maximal inhibitory concentration: > 40000 nM
Compound 4: a limit, no number (the forecaster's own chance of this, stated with the estimate: 80%); the middle value is on the limit's open side.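

In this assay compound 4 gives > 40000 nM, which is a limit of the assay and not a number. For the compounds shown here, no step from compound 1, compound 2 or compound 3 to compound 4 can be read, because all four compounds sit at the same limit: the limit of > 40000 nM in this assay, at which 4 of the 4 values shown sit. The compounds shown leave open how the group on the aromatic nitrogen moves the read-out.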